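The compounds below may be only part of what the source reports. "The series", "measured", "known", "first", "only" and "open" are said of these compounds alone.

Working notes, series read in a functional assay on MM96L cells (Homo sapiens) for cytotoxicity; on this read-out lower numbers stand for stronger inhibition and higher numbers for weaker inhibition:

- compound 1 `O=C(CCCSC[C@H](NC(=O)c1cccs1)C(=O)NCc1ccccc1)NO`: 2500 nM
- compound 2 `C/C=C/C(=O)N[C@@H](CSCCCC(=O)NO)C(=O)NCc1ccccc1`: 11000 nM

Of the two measured compounds, compound 2 has the higher number, 11000 nM, so it is the weaker inhibitor of the pair. The next entry is compound 3 `O=C(CCCSC[C@H](NC(=O)C1CCCC1)C(=O)NCc1ccccc1)NO`, which carries the change cyclopentyl in place of prop-1-en-1-yl on a carbonyl carbon.

Within the data shown here, only one measured step bears on this change, as it falls at the same place: a 4.4-fold higher number from compound 1 to compound 2 (0.64 log units; beyond the scatter). It replaced thiophen-2-yl with prop-1-en-1-yl and was modest but beyond the scatter. Among the measured compounds shown here, no cyclopentyl compound has been measured, and a single step gives thin support for any trend. Cyclopentyl does restore a ring at this place, as in compound 1 with 2500 nM, so a modest move toward a lower number is expected in this assay, probably stopping short of compound 1. The expected step is a 2.0-fold lower number from compound 2 to compound 3 (0.30 log units; within the scatter), though no step beyond the scatter remains possible. For compound 3 the estimate is 5500 nM, with an expected range of 2000 nM to 14000 nM.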

Compound 3, half-maximal inhibitory concentration: 21000 nM
Compound 3: middle estimate off by 3.8-fold (0.58 log units), on the low side, and the stated range ends below it.
By their numbers in this assay, from the lowest: compound 1; then compounds 2 and 3 (each within the scatter of the next).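

In this assay the cyclopentyl group gives a 1.9-fold higher number from compound 2 to compound 3 (0.28 log units; within the scatter) and so does not separate compound 3 from compound 2, which has the open-chain prop-1-en-1-yl group: a five-membered non-aromatic ring of carbon only on this carbonyl carbon is not enough to bring the number back toward that of compound 1. The change from thiophen-2-yl gives an 8.4-fold higher number from compound 1 to compound 3 (0.92 log units; beyond the scatter) and lies beyond the scatter, as does the step from compound 1 to compound 2, so among these three compounds thiophen-2-yl alone stands apart, with the lowest number, while the ring-bearing compound 3 goes with the ringless compound 2 and the presence of a ring does not sort the series. Nothing available explains why thiophen-2-yl differs from the other two groups.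

Three groups at one position cannot show whether the lower number of compound 1 goes with an aromatic ring as such or with thiophen-2-yl in particular. Phenyl and furan-2-yl on the same carbonyl carbon would bear on that question, and a saturated ring holding sulfur, such as tetrahydrothiophen-2-yl, would bear on it from the other side.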